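This account rests on a few compounds, and the source may have more. Where it says the series, first, only, none or still open, it means among the compounds named here.

Compound 1 `ClCc1ccc(Cn2cnc3c(Cl)ncnc32)cc1` is the starting point, yet in a functional assay on T47D cells (Homo sapiens) for cytotoxicity, read by sulforhodamine B assay, with a stated time of 48 h (a higher number here means that more compound is tolerated, a lower number that less compound is tolerated), compound 1 gives "not determined" (no result reported), so no number stands for it. Among the compounds with values here, the one measured relative is compound 2 `ClCc1ccccc1Cn1cnc2ncnc(Cl)c21`, which in this assay gives 4260 nM. Compound 3 `ClCc1ccc(Cn2cnc3c(Cl)nc(Cl)nc32)cc1` differs from compound 1 by chloro in place of hydrogen on an aromatic carbon. Within the data shown here, no measured pair shows what this change does, so only a guess is possible: a step in this assay no larger than the usual scatter, in either direction, is expected. Resting on what compound 2 shows, compound 3 is expected to give about 3500 nM in this assay, within a range from 900 nM to 14000 nM.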

Compound 3, concentration lethal to 50% of the cells: > 100000 nM
Compound 3 gave a limit, no number (the forecaster's own chance of this, stated with the estimate: 10%); middle value at least 28-fold (1.45 log units) from the limit.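

In this assay compound 3 gives > 100000 nM, a limit and not a number. Within the data shown here, no step from compound 1 to compound 3 can be read, as compound 1 has no number. Going by these compounds, what the added chloro does to the lethal concentration stays open.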